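Halogen to methyl swap on the fused ring: Emax notes

This account rests on a few compounds, and the source may have more. Where it says the series, first, only, none or still open, it means among the compounds named here.

Measured so far:
- compound 1, `CC#C[C@@H](CC(=O)O)c1ccc(OC[C@H]2COc3ccc(Cl)cc3O2)cc1`: 86%
- compound 2, `CC#C[C@@H](CC(=O)O)c1ccc(OC[C@H]2COc3ccc(Br)cc3O2)cc1`: 69%

In a functional assay on HEK293 cells for agonist activity at Free fatty acid receptor 1 (Homo sapiens), read by fluorescence and calcium flux, with a stated time of 10 min (on this read-out higher numbers stand for larger maximal responses and lower numbers for smaller maximal responses), compound 1 gives 86% and compound 2 gives 69%. Going by the values given here, the single measured step is a number 17 percentage points lower from compound 1 to compound 2 (beyond the scatter). On the numbers shown, compound 2 stands lowest of the two, with compound 1 as its only neighbour, a number beyond the scatter higher.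

Compound 3, `CC#C[C@@H](CC(=O)O)c1ccc(OC[C@H]2COc3ccc(C)cc3O2)cc1`, has not been measured. Compared with compound 2 the change is methyl in place of bromo on an aromatic carbon.

Among the compounds with values here, the only step that bears on this position is a number 17 percentage points lower from compound 1 to compound 2 (beyond the scatter), a change from one halogen to another, which is not the same kind of change as bromo to methyl. Within the data shown here, no step with methyl at this position has been measured, so the direction of the step from compound 2 to compound 3 in this assay cannot be read from the data. The two halogen values span a modest range, and a step within that range, or none beyond the scatter, is what is expected here.

For compound 3 in this assay the expected step is a number 6 percentage points higher from compound 2 to compound 3 (within the scatter), a change that is not expected to go beyond the scatter.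

Compound 3 is therefore estimated at 75%, with a range from 55% to 95%.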

Compound 3, largest response reached (Emax), in percent of the reference or control that the assay uses: 78%
Compound 3: middle estimate off by 3 percentage points, on the low side; measured number inside the range.
By their numbers in this assay, from the lowest: compounds 2, 3 and 1 (each within the scatter of the next, the first and the last beyond it).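

In this assay, methyl in place of bromo gives a number 9 percentage points higher from compound 2 to compound 3 (within the scatter) and methyl in place of chloro gives a number 8 percentage points lower from compound 1 to compound 3 (within the scatter). Going by these compounds alone, this is the first non-halogen group seen on this aromatic carbon, and with both steps inside the scatter, compound 3 cannot be separated from either halogen compound, even though the two halogen compounds differ from each other by a number 17 percentage points lower from compound 1 to compound 2 (beyond the scatter). A halogen at this place is therefore not required for a large maximal response in these three compounds, and nothing available explains the numbers.

From the compounds shown here alone, whether a methoxy group, an amine or a longer chain such as ethyl on the same carbon would keep the maximal response in this range remains open, as does the effect of hydrogen at this place. Maximal response alone also leaves open how the three compounds compare in potency, so the equivalence of methyl and the halogens holds only for the size of the response in this assay.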